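This account rests on a few compounds, and the source may have more. Where it says the series, first, only, none or still open, it means among the compounds named here.

Measured in a functional assay on cells (Cancer cell lines, Homo sapiens) for inhibition; a lower number here means a stronger inhibitor of growth, a higher number a weaker inhibitor of growth:

Compound 1 `N=C(N)N/N=C/c1c(-c2ccsc2)nc2sccn12` gives 14100 nM
Compound 2 `N=C(N)N/N=C/c1c(-c2cccs2)nc2sccn12` gives 9770 nM

Only these two numbers exist so far, and compound 2 stands level with compound 1 within the scatter. The next compound, compound 3 `Cc1cc(-c2nc3sccn3c2/C=N/NC(=N)N)c(C)s1`, keeps the shared core and differs from compound 2 in one group: 2,5-dimethylthiophen-3-yl in place of thiophen-2-yl on an aromatic carbon. Within the data shown here, the only measured guide is a 1.4-fold lower number from compound 1 to compound 2 (0.16 log units; within the scatter), which exchanges thiophen-3-yl for thiophen-2-yl. Among the measured compounds shown here, no measured compound carries a 2,5-dimethylthiophen-3-yl group, so this guide is weak and the range must stay wide. In this assay no change beyond the scatter is expected in either direction. The expected change is a 1.2-fold lower number from compound 2 to compound 3 (0.09 log units; within the scatter). For compound 3 the estimated value is 8000 nM, with an expected range from 2500 nM to 25000 nM.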

Compound 3, concentration for 50% growth inhibition: 15500 nM
Estimate against measurement, compound 3: 1.9-fold (0.29 log units) below, within the range that was stated.
By their numbers in this assay, from the lowest: compounds 2, 1 and 3 (each within the scatter of the next).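

In this assay, placing 2,5-dimethylthiophen-3-yl on this aromatic carbon gives a 1.6-fold higher number from compound 2 to compound 3 (0.20 log units; within the scatter), and the comparison with the unsubstituted thiophen-3-yl gives a 1.1-fold higher number from compound 1 to compound 3 (0.04 log units; within the scatter). The earlier compounds shown here showed only that the point of attachment of a plain thiophene made no difference beyond the scatter; these steps extend that to a thiophene carrying two methyl groups, so compound 1, compound 2 and compound 3 all stand level at this position. Nothing measured here offers an explanation for these numbers.

On these data alone, all three compounds carry a thiophene at this position, so it remains open whether a phenyl ring, an amine or a carboxylic acid there would shift the number beyond the scatter. As far as these compounds go, it also remains open whether any change to the shared core would do so.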